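Moving a Hydroxyl Group on Two Related Cores

A few compounds are considered here, and "the series" means these few. Any claim that something is new, unique, unknown or untested is made for them only; others in the source may bear on it.

Compound 1 `Oc1cccc(-c2cc(-c3ccccc3)cc(-c3ccsc3)n2)c1` and compound 2 `Oc1ccc(-c2cc(-c3ccccc3)cc(-c3ccsc3)n2)cc1` share one core and differ only in where the hydroxyl sits. In a functional assay on HeLa cells (Homo sapiens) for cytotoxicity, read by ELISA, with a stated time of 2 days (on this read-out lower numbers stand for stronger inhibition and higher numbers for weaker inhibition), compound 1 gives 13800 nM, and compound 2 gives 17300 nM. The change between them is 4-hydroxyphenyl in place of 3-hydroxyphenyl on an aromatic carbon, and it made a 1.3-fold higher number from compound 1 to compound 2 (0.10 log units; within the scatter). Compound 3 `Oc1cccc(-c2cc(-c3ccccc3)nc(-c3ccco3)c2)c1` is built on a different core; the difference between the two cores is not broken down here. In this assay compound 3 gives 10900 nM. Compound 4 `Oc1ccc(-c2cc(-c3ccccc3)nc(-c3ccco3)c2)cc1` has not yet been measured. It differs from compound 3 by 4-hydroxyphenyl in place of 3-hydroxyphenyl on an aromatic carbon. The surroundings are not word for word the same as in the first pair: there the hydroxyphenyl sat next to the ring nitrogen and meta to a thiophen-3-yl group, here it sits opposite the ring nitrogen and meta to a furan-2-yl group, so this is the same kind of change rather than the same one. For compound 4 the expected step is a 1.3-fold higher number from compound 3 to compound 4 (0.11 log units; within the scatter), which rests on the measured 1.3-fold higher number from compound 1 to compound 2 (0.10 log units; within the scatter) and on the same kind of change being made. Compound 4 is therefore estimated to give 14000 nM in this assay, most likely between 7000 nM and 28000 nM.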

Compound 4, half-maximal inhibitory concentration: 4500 nM
Compound 4: middle estimate off by 3.1-fold (0.49 log units), on the high side; measured number below the stated range.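

In this assay, moving the hydroxyl from the 3-hydroxyphenyl to the 4-hydroxyphenyl arrangement on the core of compound 3 gave a 2.4-fold lower number from compound 3 to compound 4 (0.38 log units; beyond the scatter), so this change cannot simply be carried from one core to the other in this series. Set side by side, the two steps clearly differ: the same change on two cores in this assay, a 1.3-fold higher number (0.10 log units; within the scatter) from compound 1 to compound 2 and a 2.4-fold lower number (0.38 log units; beyond the scatter) from compound 3 to compound 4, 3.0-fold (0.48 log units) apart, beyond the scatter of two such steps. This does not show what makes them differ, since on the core of compound 3 the hydroxyphenyl sits opposite the ring nitrogen and meta to a furan-2-yl group, the surroundings are not the same as on the first core, and a single pair on each core cannot separate these features or predict the step on a third core.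

The compounds shown leave open how a methoxy group or an amine in place of the hydroxyl would read in this assay. They also leave open whether the 4-hydroxyphenyl group would still give the lower number if a thiophen-3-yl group replaced the furan-2-yl group on the core of compound 4.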